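An Added Methoxy Group and Paw Swelling in Rats

The source may hold more compounds than are shown below. What is called first, only, known or untested is meant among the compounds shown, and "the series" means these compounds.

In a functional assay on the whole organism (strain albino) for inhibition, with Rattus norvegicus as the target, read by paw edema, with stated times of 30 min and 1 h, at a dose of 0.28 mmol/kg by the oral route (on this read-out higher numbers stand for more inhibition at the one dose given (going by the name of the read-out) and lower numbers for less inhibition), compound 1, with structure `CCn1c(SCC(=O)Nc2ccc(C(C)=O)cc2)nnc1-c1ccc(OC)c(OC)c1`, gives 56%. Compound 2, with structure `CCn1c(SCC(=O)Nc2ccc(C(C)=O)cc2)nnc1-c1cc(OC)c(OC)c(OC)c1`, differs from it in one place: methoxy in place of hydrogen on an aromatic carbon. In this assay compound 2 gives 46%, so the step is a number 10 percentage points lower from compound 1 to compound 2 (within the scatter). Compound 3, with structure `C=CCn1c(SCC(=O)Nc2ccc(/C(C)=N/O)cc2)nnc1-c1ccc(OC)c(OC)c1`, is built on a core that differs from the core of compound 1, and the difference between the two cores is not broken down here. In this assay compound 3 gives 53%, a number that lies within the usual scatter of both compound 1 and compound 2.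

Compound 4, with structure `C=CCn1c(SCC(=O)Nc2ccc(/C(C)=N/O)cc2)nnc1-c1cc(OC)c(OC)c(OC)c1`, has not yet been measured. It differs from compound 3 in exactly the way compound 2 differs from compound 1: methoxy in place of hydrogen on an aromatic carbon. The surroundings of the place are described in the same words in both cases, so this is the same change made a second time, on a different core. Going by the values given here, the only guide to its effect is the single step seen before, which was itself within the scatter. On that basis the step of a number 8 percentage points lower from compound 3 to compound 4 (within the scatter) is expected, resting on the earlier step of a number 10 percentage points lower from compound 1 to compound 2 (within the scatter). Among the compounds with values here, with only one prior example, a flat result would be no surprise either. Compound 4 is therefore estimated to give 45% in this assay, with a plausible range from 33% to 57%.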

Compound 4, a percentage reported as inhibition, in the whole organism at one dose (the size of the read-out at that dose, not a potency): 49%
Compound 4: the middle estimate sits 4 percentage points below what was measured; low and high end bracket the measured number.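

In this assay, methoxy in place of hydrogen on an aromatic carbon, now on the second core, gives a number 4 percentage points lower from compound 3 to compound 4 (within the scatter). Set beside the earlier case, the two steps cannot be told apart, so in this small set the change reads the same on both cores: the same change on two cores in this assay, a number 10 percentage points lower (within the scatter) from compound 1 to compound 2 and a number 4 percentage points lower (within the scatter) from compound 3 to compound 4, 6 percentage points apart, within the scatter of two such steps. This does not show that the added methoxy group has a real effect on paw swelling on either core, since each step on its own lies within the scatter, and two pairs of compounds tested at a single dose cannot establish a rule for the whole series.

The compounds shown leave open what a different group at this same place on the ring would do, such as a hydroxyl group, a chlorine atom or a longer ethoxy chain, and whether any of these would give a step large enough to stand clear of the scatter. Also open, from the compounds shown here alone, is whether the methoxy change would read the same way on a third core, or at other doses and times.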